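A few compounds are considered here, and "the series" means these few. Any claim that something is new, unique, unknown or untested is made for them only; others in the source may bear on it.

Measured so far:
- compound 1 `O=C1OC[C@H](Cc2ccccc2)[C@H]1Cc1ccc(C(F)(F)F)cc1`: 29000 nM
- compound 3 `COc1ccccc1C[C@H]1COC(=O)[C@@H]1Cc1ccc(Cl)c(Cl)c1`: 24000 nM
- compound 2 `CCCCOc1cc(C[C@H]2C(=O)OC[C@@H]2Cc2ccccc2)ccc1O`: "not determined" (no result reported)

In a functional assay on HeLa cells (Homo sapiens) for cytotoxicity, read by WST assay, with a stated time of 48 h (on this read-out higher numbers stand for an effect only at larger amounts of compound and lower numbers for an effect already at smaller amounts), compound 3 gives 24000 nM, the lower of the two numbers, while compound 1 gives 29000 nM; the two lie within the scatter of each other, so they show no difference. For compound 2 no result was reported in this assay. Compound 4 `O=C1OC[C@H](Cc2ccc(F)cc2)[C@H]1Cc1ccc(Cl)c(Cl)c1` has not been measured. It differs from compound 3 in one place: 4-fluorophenyl in place of 2-methoxyphenyl on a saturated chain carbon bound to a saturated ring carbon. Among the compounds with values here, no step between measured compounds bears on this change, so the step of a 1.0-fold higher number from compound 3 to compound 4 (0.02 log units; within the scatter) is expected to stay within the scatter, in no clear direction. The estimate for compound 4 in this assay is 25000 nM, with a range from 10000 nM to 60000 nM.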

Compound 4, half-maximal effective concentration: 19000 nM
For compound 4 the middle estimate is 1.3-fold (0.12 log units) above the measured one; measured number inside the range.
By their numbers in this assay, from the lowest: compounds 4, 3 and 1 (each within the scatter of the next).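

In this assay, putting 4-fluorophenyl in place of 2-methoxyphenyl on a saturated chain carbon bound to a saturated ring carbon gives a 1.3-fold lower number from compound 3 to compound 4 (0.10 log units; within the scatter) and so no clear difference. Within the data shown here, this is the first direct reading of a change at this position, and it shows that swapping these two aromatic groups, with the loss of the hydrogen-bond acceptor of 2-methoxyphenyl, leaves the number within the scatter. No measurement here offers an explanation for this result. Still open, on these data alone, is whether an amine or a carboxylic acid in place of the aromatic ring would shift the number.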